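The source may report more compounds than this note shows. Statements on the series, on what has been measured and on what is new or still open speak of the compounds shown alone.

Working notes on the two measured compounds and the next one.

Compound 2 `CCC(OC)C1=C(N2CC2)C(=O)C(C)=C(N2CC2)C1=O` stands lowest of the two numbers in a functional assay on L1210 cells (Mus musculus), with a stated time of 12 days; a higher number here means a more potent compound, by a factor of ten per unit of this negative logarithm, a lower number a less potent compound: compound 2 gives 5.68, whereas compound 1 `CC1=C(N2CC2)C(=O)C(CCCOC(N)=O)=C(N2CC2)C1=O` gives 6.18. Within the data shown here, the only measured step in this assay is a number 0.50 log units lower from compound 1 to compound 2 (beyond the scatter), a change on a double-bonded ring carbon.

Compound 3 `COC(CO)C1=C(N2CC2)C(=O)C(C)=C(N2CC2)C1=O` differs from compound 2 by hydroxy in place of methyl on a saturated chain carbon, two bonds along the chain from a double-bonded ring carbon and an oxygen on a saturated carbon. Among the measured compounds shown here, no measured step bears directly on this change: the single step on record, a number 0.50 log units lower from compound 1 to compound 2 (beyond the scatter), exchanges a chain on a double-bonded ring carbon, not a group on a saturated chain carbon, and it was modest. With nothing closer to lean on, the expectation for compound 3 in this assay is a step of a number 0.02 log units higher from compound 2 to compound 3 (within the scatter), that is, none beyond the scatter, with wide uncertainty. Compound 3 is therefore estimated at 5.7, expected to fall between 5.1 and 6.3.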

Compound 3, logarithm of the reciprocal of the active concentration, log(1/C): 6.9
Estimate against measurement, compound 3: 1.20 log units below, outside the stated range (above it).
By their numbers in this assay, from the lowest: compound 2; then compound 1; then compound 3.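

In this assay, the change from ethyl to hydroxymethyl gives a number 1.22 log units higher from compound 2 to compound 3 (beyond the scatter), so replacing one heavy atom at this saturated chain carbon can shift potency substantially. The 2-hydroxy-1-methoxyethyl chain also reverses the order set by the 1-methoxypropyl chain relative to compound 1, with a number 0.72 log units higher from compound 1 to compound 3 (beyond the scatter), and compound 3 now has the highest number of the three, with its steps to both others beyond the scatter. No measurement at hand accounts for the size of this step.

The compounds shown leave open whether the step is specific to hydroxy or would also appear with an amine or a carboxylic acid on the same saturated chain carbon. They also leave open whether a longer chain ending in hydroxy would keep this potency.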